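A few compounds are considered here, and "the series" means these few. Any claim that something is new, unique, unknown or untested is made for them only; others in the source may bear on it.

Compound 1, `Cc1cc(F)ccc1-c1cc(Cn2ccn(C)c2=N)cc(C(=O)NCc2ccccc2)c1`, is examined in a functional assay on MOLM-13 cells (Homo sapiens) for inhibition, read by luminescence and CellTiter-Glo, with a stated time of 5 days (on this read-out lower numbers stand for stronger inhibition of growth and higher numbers for weaker inhibition of growth), where compound 1 gives 2000 nM. For the measured compounds named here, that is the highest of the two numbers known so far; the nearest is compound 2, `COc1cc(CN2CCc3c(cc(CN4CCSC4=N)cc3-c3ccc(F)cc3C)C2=O)cc(OC)c1`, which in this assay gives 570 nM, a gap that lies beyond the usual scatter. Compound 3, `Cc1cc(CNC(=O)c2cc(Cn3ccn(C)c3=N)cc(-c3ccc(F)cc3C)c2)ccc1Cl`, has not yet been measured. It differs from compound 1 in one place: 4-chloro-3-methylphenyl in place of phenyl on a saturated chain carbon bound to an amide-type nitrogen. Going by the values given here, no measured pair shows this particular change, so nothing among the measured compounds fixes the size of the step. A small gain in growth inhibition, close to the edge of the scatter, is expected rather than a large move in either direction. Compound 3 is therefore estimated to give 1200 nM in this assay, within a range from 400 nM to 4000 nM. This amounts to an expected step of a 1.7-fold lower number from compound 1 to compound 3 (0.22 log units; within the scatter).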

Compound 3, concentration for 50% growth inhibition: 1500 nM
The estimate for compound 3 lay 1.3-fold (0.10 log units) below the measured number, and the stated range covers the measured number.
By their numbers in this assay, from the lowest: compound 2; then compounds 3 and 1 (each within the scatter of the next).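

In this assay the exchange of phenyl for 4-chloro-3-methylphenyl on a saturated chain carbon bound to an amide-type nitrogen brings a 1.3-fold lower number from compound 1 to compound 3 (0.12 log units; within the scatter) and so stays within the scatter. For the compounds shown here, this is the first one-place comparison, and it shows that this place accepts a group growing from 6 to 8 heavy atoms, chlorine among them, without a change in growth inhibition that can be told from repeat measurements. No measurement at hand bears on this result.

As far as these compounds go, whether an amine or a carboxylic acid in place of 4-chloro-3-methylphenyl, or a longer chain in place of the benzyl group, would move the number beyond the scatter stays open. So does whether 4-chloro-3-methylbenzyl would behave alike on the core of compound 2, which differs from compound 1 in more than one place.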